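A few compounds are considered here, and "the series" means these few. Any claim that something is new, unique, unknown or untested is made for them only; others in the source may bear on it.

Within the data shown here, in a functional assay on A549 cells (Homo sapiens) for inhibition, read by MTT assay, with a stated time of 72 h (a higher number here means a weaker inhibitor, a lower number a stronger inhibitor), compound 1 `CCc1ccc(NC(=O)C2CCN(C/C=C/c3ccccc3)CC2)cc1` gives 19600 nM, and compound 2 `CC(C)c1ccc(NC(=O)C2CCN(C/C=C/c3ccccc3)CC2)cc1` gives 9430 nM, the lower of the two numbers so far. Compound 3 `CCCCCc1ccc(NC(=O)C2CCN(C/C=C/c3ccccc3)CC2)cc1` keeps the shared core but has pentyl in place of isopropyl on an aromatic carbon. Among the measured compounds shown here, only one measured step bears on this change. That step, a 2.1-fold lower number from compound 1 to compound 2 (0.32 log units; beyond the scatter), was modest, and it came with methyl in place of hydrogen on the chain. One step is thin evidence, so the expected change is small, lower if anything, and perhaps within the scatter. The expected move is a 1.3-fold lower number from compound 2 to compound 3 (0.10 log units; within the scatter). For compound 3 the estimate is 7500 nM, with an expected range from 2800 nM to 20000 nM.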

Compound 3, half-maximal inhibitory concentration: 3880 nM
Estimate against measurement, compound 3: 1.9-fold (0.29 log units) above; the measured number falls inside the stated range.
By their numbers in this assay, from the lowest: compound 3; then compound 2; then compound 1.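

Replacing isopropyl with pentyl on this aromatic carbon gives a 2.4-fold lower number from compound 2 to compound 3 (0.39 log units; beyond the scatter) and shows that the number keeps falling beyond the branched group. Over the larger change in the same place, the series shows a 5.1-fold lower number from compound 1 to compound 3 (0.70 log units; beyond the scatter) and, across these three compounds, the number falls as the group grows in heavy atoms, with no compound going against this. Nothing measured here explains this trend.

From the compounds shown here alone, whether the fall continues with a longer chain such as octyl remains open. So does whether it would survive an amine or a carboxylic acid at the end of the chain.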